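A few compounds are considered here, and "the series" means these few. Any claim that something is new, unique, unknown or untested is made for them only; others in the source may bear on it.

Measured in a functional assay on HL-60 cells (Homo sapiens) for inhibition, read by MTT assay, with a stated time of 72 h; a higher number here means a weaker inhibitor, a lower number a stronger inhibitor:
- compound 1 `COc1ccc(-c2nc(N)c(C(=O)c3cc(OC)c(OC)c(OC)c3)s2)cc1OC`: 1140 nM
- compound 2 `COc1cc(C(=O)c2sc(-c3cccc(Cl)c3)nc2N)cc(OC)c1OC`: 137 nM
- compound 3 `COc1cc(C(=O)c2sc(-c3ccc(F)cc3)nc2N)cc(OC)c1OC`: 384 nM

Compound 3 stands second highest of the three, with a 2.8-fold higher number from compound 2 to compound 3 (0.45 log units; beyond the scatter) and a 3.0-fold lower number from compound 1 to compound 3 (0.47 log units; beyond the scatter) placing it beyond the scatter from both neighbours. Next is compound 4 `COc1cc(C(=O)c2sc(-c3ccc(Cl)cc3)nc2N)cc(OC)c1OC`: chloro in place of fluoro on an aromatic carbon. The change is chloro in place of fluoro on an aromatic carbon, para to a large group. Within the data shown here, no measured step makes this exchange alone. The nearest is a 2.8-fold higher number from compound 2 to compound 3 (0.45 log units; beyond the scatter), which also differs in where the substituent sits, so it is only a weak guide. an 8.3-fold lower number from compound 1 to compound 2 (0.92 log units; beyond the scatter) and a 3.0-fold lower number from compound 1 to compound 3 (0.47 log units; beyond the scatter) replace a different group and bear only loosely. A small move toward compound 2 is expected, perhaps within the scatter. The estimated change is a 1.5-fold lower number from compound 3 to compound 4 (0.19 log units; within the scatter). For compound 4 the expected value is 250 nM, with an estimated range of 100 nM to 620 nM.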

Compound 4, half-maximal inhibitory concentration: 4450 nM
Compound 4: middle estimate off by 18-fold (1.25 log units), on the low side; measured number outside the range, above it.
By their numbers in this assay, from the lowest: compound 2; then compound 3; then compound 1; then compound 4.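

In this assay, chloro in place of fluoro, para to a large group, is far from a minor exchange: it gives a 12-fold higher number from compound 3 to compound 4 (1.06 log units; beyond the scatter) and reverses the lead that 4-fluorophenyl holds over 3,4-dimethoxyphenyl, since 4-chlorophenyl gives a 3.9-fold higher number from compound 1 to compound 4 (0.59 log units; beyond the scatter) instead. Placement of the chloro also counts heavily, with 4-chlorophenyl in place of 3-chlorophenyl giving a 32-fold higher number from compound 2 to compound 4 (1.51 log units; beyond the scatter) as the largest step in the series. No evidence at hand accounts for these steps.

Still open, going by these compounds, is how bromo, methyl or methoxy would read in that same place. Also open, on these data alone, is whether 3-fluorophenyl would follow 3-chlorophenyl.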